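The source may hold more compounds than are shown below. What is called first, only, known or untested is meant among the compounds shown, and "the series" means these compounds.

Three compounds have been measured in a functional assay on CEM-CCRF cells for antagonist activity at C-X-C chemokine receptor type 4 (Homo sapiens), read by calcium flux; on this read-out higher numbers stand for weaker inhibition and lower numbers for stronger inhibition:

compound 1 `NCc1cc(F)ccc1CN(Cc1nc2ccccc2[nH]1)C1CCCc2cccnc21` gives 219 nM
compound 2 `NCc1cc(C(F)(F)F)ccc1CN(Cc1nc2ccccc2[nH]1)C1CCCc2cccnc21` gives 51 nM
compound 3 `NCc1cc(C(=O)O)ccc1CN(Cc1nc2ccccc2[nH]1)C1CCCc2cccnc21` gives 126 nM

Compound 3 stands second highest of the three numbers. Toward compound 1 the step is small, a 1.7-fold lower number from compound 1 to compound 3 (0.24 log units; within the scatter), and falls within the scatter, so the two cannot be ordered. Toward compound 2 the gap is larger, a 2.5-fold higher number from compound 2 to compound 3 (0.39 log units; beyond the scatter), and lies beyond the scatter.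

The next compound, compound 4 `NCc1occc1CN(Cc1nc2ccccc2[nH]1)C1CCCc2cccnc21`, differs from compound 3 by a group of 7 heavy atoms (5 carbon, 1 nitrogen, 1 oxygen; one five-membered aromatic ring with 1 hetero atom) in place of a group of 11 heavy atoms (8 carbon, 1 nitrogen, 2 oxygen; one six-membered aromatic ring of carbon only), on a saturated chain carbon bound to an amine nitrogen. For the measured compounds named here, none of the measured steps covers a change of this kind: all three measured compounds share the six-membered ring and vary only the group on it, the widest difference among them being a 4.3-fold lower number from compound 1 to compound 2 (0.63 log units; beyond the scatter). These steps show that changes in this part of the molecule move the number by modest amounts, but they give no direct guide to the exchange of the whole ring. The expectation is therefore uncertain and is placed near the value of compound 3, leaning toward a somewhat higher number, a step of about a 2.4-fold higher number from compound 3 to compound 4 (0.38 log units; beyond the scatter) in this assay. For compound 4 the estimated value in this assay is 300 nM, with a range from 100 nM to 1000 nM.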

Compound 4, half-maximal inhibitory concentration: 21 nM
Compound 4: the middle estimate sits 14-fold (1.15 log units) above what was measured, outside the stated range (below it).
By their numbers in this assay, from the lowest: compound 4; then compound 2; then compounds 3 and 1 (each within the scatter of the next).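

In this assay, replacing the whole group that holds the six-membered aromatic ring of carbon only with the group of 7 heavy atoms, which holds one five-membered aromatic ring with 1 hetero atom, gives a 6.0-fold lower number from compound 3 to compound 4 (0.78 log units; beyond the scatter) and a 10-fold lower number from compound 1 to compound 4 (1.02 log units; beyond the scatter). The earlier compounds shown here varied only the substituent on the six-membered ring, so they could not show that this ring can be exchanged at all; here, on a saturated chain carbon bound to an amine nitrogen, the smaller group gives a lower number than either of the two larger groups it is compared with, and the larger step is the one rated large. Nothing available bears on the reason for this shift.

The compounds shown leave open whether the lower number belongs to the five-membered ring itself or would survive further substitution, since none of them carries fluoro, trifluoromethyl or carboxy on that ring. They also leave open what a nitrile or a methyl group on the five-membered ring would do to the number in this assay.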